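Aryl halogen change on the spiro core

This account rests on a few compounds, and the source may have more. Where it says the series, first, only, none or still open, it means among the compounds named here.

Compound 1 `C[C@H](c1ccc(C(=O)NCCC(=O)O)cc1)N1C(=O)C(c2cccc(F)c2)=N[C@]12CC[C@@H](C(C)(C)C)CC2` is the stronger of the two compounds measured in an assay on membranes from liver for displacement of a labelled ligand from Glucagon receptor (Mus musculus), read by scintillation counting, with a stated time of 60 min (a lower number here means a stronger inhibitor, a higher number a weaker inhibitor), where compound 1 gives 4400 nM. Compound 2 `CC(C)(C)[C@H]1CC[C@]2(CC1)N=C(c1ccc(C(F)(F)F)cc1)C(=O)N2Cc1ccc(C(=O)NCCC(=O)O)cc1` differs from compound 1 in several places at once; in this assay compound 2 gives 9600 nM, a weaker result. Compound 3 `C[C@H](c1ccc(C(=O)NCCC(=O)O)cc1)N1C(=O)C(c2cccc(Cl)c2F)=N[C@]12CC[C@@H](C(C)(C)C)CC2` is not yet measured. It carries 3-chloro-2-fluorophenyl in place of 3-fluorophenyl on a carbon with a double bond to nitrogen; the remainder of the shared core is unchanged. For the measured compounds named here, no single-point step between measured compounds exists to calibrate this change, so the expectation rests on the two values alone. The change is expected to give a small lowering of the number, near the edge of the usual scatter, a 2.0-fold lower number from compound 1 to compound 3 (0.30 log units; within the scatter), rather than no change or a rise. Compound 3 is therefore estimated at 2200 nM in this assay, with a range from 700 nM to 7000 nM.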

Compound 3, half-maximal inhibitory concentration: 4000 nM
The estimate for compound 3 lay 1.8-fold (0.26 log units) below the measured number; low and high end bracket the measured number.
By their numbers in this assay, from the lowest: compounds 3 and 1 (each within the scatter of the next); then compound 2.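

In this assay, the exchange of 3-fluorophenyl for 3-chloro-2-fluorophenyl on the carbon with a double bond to nitrogen gives a 1.1-fold lower number from compound 1 to compound 3 (0.04 log units; within the scatter), so the two groups cannot be told apart here. This is the only comparison shown that isolates this position, and it shows that the added chlorine and the altered fluorine placement leave the number within the scatter, with the one aromatic ring kept. No measured data bear on why this exchange leaves the number within the scatter.

Compound 2 differs from compound 1 in several places, so its value gives no separate reading of this position. As far as these compounds go, whether a nitrile or an amine on this phenyl, or a pyridine ring in its place, would shift the number beyond the scatter remains open.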